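The source may hold more compounds than are shown below. What is called first, only, known or untested is meant among the compounds shown, and "the series" means these compounds.

Measured in a functional assay on HepG2 cells (Homo sapiens) for cytotoxicity, read by MTT assay, with a stated time of 72 h; a higher number here means a weaker inhibitor, a lower number a stronger inhibitor:
Compound 1 `CC(C)n1c(Nc2ccccc2)nc2cnc(Nc3ccc(N4CCN(C)CC4)cc3)nc21`: > 5000 nM
Compound 2 `CN1CCN(c2ccc(Nc3ncc4nc(Nc5ccccc5)n(-c5ccccc5)c4n3)cc2)CC1`: > 5000 nM
Compound 3 `CC1CCN(c2ccc(Nc3ncc4nc(Nc5ccccc5)n(C5CCCC5)c4n3)cc2)CC1`: > 5000 nM

Each of these entries is a limit of the assay, not a number. Compound 3 therefore has no exact position in this set, only its limit of > 5000 nM.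

The next step leads to compound 4 `CC(=O)Nc1ccc(Nc2ncc3nc(Nc4ccccc4)n(C4CCCC4)c3n2)cc1`, where acetamido takes the place of 4-methylpiperidin-1-yl on an aromatic carbon: acetamido in place of 4-methylpiperidin-1-yl on an aromatic carbon.

Going by the values given here, only one measured step offers any comparison, a step that the two limits leave unreadable from compound 1 to compound 2, and it is a different change, phenyl in place of isopropyl on an aromatic nitrogen. Its size cannot be read, so it gives no guide to the size or direction of this step. The remaining evidence is the limit of > 5000 nM in this assay, at which 3 of the 3 values shown sit. On that basis, compound 4 is expected to stay in the same weak range in this assay and may well give a limit too.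

The expected change is a step that the limit leaves unreadable from compound 3 to compound 4, with no firm direction.

For compound 4, the estimated value is 6000 nM, with an expected range from 2000 nM to 15000 nM.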

Compound 4, half-maximal inhibitory concentration: > 5000 nM
Compound 4 ended at the assay's limit (the forecaster's own chance of this, stated with the estimate: 75%); the middle value does not contradict the limit.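

Compound 3 and compound 4 both give only a limit in this assay, not a number, so the step between them cannot be read. The compounds shown leave open which change, if any, would bring a readable value: the limit of > 5000 nM in this assay, at which 4 of the 4 values shown sit.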